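Pyridin-4-yl for Pyridin-3-yl: Expected Cytotoxicity of Compound 3

A few compounds are considered here, and "the series" means these few. Any claim that something is new, unique, unknown or untested is made for them only; others in the source may bear on it.

Measured so far:
compound 1 `O=C(Nc1ccccc1)c1cccc2[nH]c(-c3cccnc3)nc12`: 34.2 uM
compound 2 `O=C(Nc1ccccc1F)c1cccc2[nH]c(-c3cccnc3)nc12`: 54.7 uM

Going by the values given here, in an ADME assay on Vero cells (Chlorocebus sabaeus) for cytotoxicity (on this read-out higher numbers stand for lower toxicity in this test and lower numbers for higher toxicity in this test), compound 2 gives 54.7 uM, and the only measured step, a 1.6-fold higher number from compound 1 to compound 2 (0.20 log units; within the scatter), leaves it indistinguishable from compound 1. Compound 3 `O=C(Nc1ccccc1F)c1cccc2[nH]c(-c3ccncc3)nc12` differs from compound 2 by pyridin-4-yl in place of pyridin-3-yl on an aromatic carbon. Among the compounds with values here, no measured step touches this change; the fluoro-for-hydrogen step is the sole comparison available and was itself within the scatter. Compound 3 is therefore expected to show no shift beyond the scatter, an estimated step of a 1.1-fold lower number from compound 2 to compound 3 (0.04 log units; within the scatter). The estimate for compound 3 in this assay is 50 uM, with a range from 20 uM to 130 uM.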

Compound 3, half-maximal toxic concentration: 111 uM
Beside the measured number, compound 3's estimate is 2.2-fold (0.35 log units) below it, and the stated range covers the measured number.
By their numbers in this assay, from the lowest: compounds 1 and 2 (each within the scatter of the next); then compound 3.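

In this assay, pyridin-4-yl in place of pyridin-3-yl on this aromatic carbon between two ring nitrogen atoms gives a 2.0-fold higher number from compound 2 to compound 3 (0.31 log units; beyond the scatter), the first step among these compounds to lie beyond the scatter, though only modestly. The two groups have the same counted atoms, donors and acceptors, so counts alone do not separate them at this position. Nothing available explains the difference. From the compounds shown here alone, it remains open whether pyridin-2-yl, plain phenyl or a piperidine at this carbon would change the number, and whether the same swap would give a similar step on compound 1.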